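Replacing a terminal phenyl with tert-butyl in a sulfonamide

A few compounds are considered here, and "the series" means these few. Any claim that something is new, unique, unknown or untested is made for them only; others in the source may bear on it.

Compound 1 `CCCN(CC[C@H]1CC[C@H](NC(=O)c2cccc(-n3cncn3)c2)CC1)[C@H]1CCc2nc(N)sc2C1`: 3 nM
Compound 2 `CCCN(CC[C@H]1CC[C@H](NS(=O)(=O)c2ccc(-c3ccccc3)cc2)CC1)[C@H]1CCc2nc(N)sc2C1`: 41 nM

In an assay on brain for displacement of a labelled ligand from D(3) dopamine receptor (Rattus norvegicus) (a higher number here means a weaker inhibitor, a lower number a stronger inhibitor), compound 2 gives 41 nM, the higher of the two numbers measured. Compound 1 gives 3 nM, a lower number beyond the scatter. Compound 3 `CCCN(CC[C@H]1CC[C@H](NS(=O)(=O)c2ccc(C(C)(C)C)cc2)CC1)[C@H]1CCc2nc(N)sc2C1` differs from compound 2 by tert-butyl in place of phenyl on an aromatic carbon. Among the measured compounds shown here, no measured pair shows this change, so its effect is unknown from the data. The step of a 1.6-fold higher number from compound 2 to compound 3 (0.20 log units; within the scatter) is expected to be modest, toward a somewhat higher number, with a step within the scatter also plausible. Compound 3 is estimated at 65 nM, with a range from 15 nM to 280 nM.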

Compound 3, inhibition constant: 5 nM
Beside the measured number, compound 3's estimate is 13-fold (1.11 log units) above it; measured number below the stated range.
By their numbers in this assay, from the lowest: compounds 1 and 3 (each within the scatter of the next); then compound 2.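

Tert-butyl in place of phenyl on this aromatic carbon gives an 8.2-fold lower number from compound 2 to compound 3 (0.91 log units; beyond the scatter) in this assay. At this position, then, a low number does not depend on the outer six-membered aromatic ring: a group with no ring and fewer heavy atoms serves here, and the 4-phenylphenyl of compound 2 is the less favourable of the two. Nothing available accounts for the size of this step.

Going by these compounds, what a cyclohexyl ring, an isopropyl group or a methoxy group would do on the same carbon stays open. On these data alone, it also stays open whether the step depends on the branching of tert-butyl or only on the loss of the phenyl.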